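Swapping a Para Bromine for a Phenyl Ring

This account rests on a few compounds, and the source may have more. Where it says the series, first, only, none or still open, it means among the compounds named here.

Compound 1 `CC(C)(C)c1ccc(CNCCCNS(=O)(=O)c2cc(C(F)(F)F)cc(C(F)(F)F)c2)cc1` was tested in a functional assay on HPAC cells (Homo sapiens) for inhibition, read by MTT assay, with a stated time of 72 h (on this read-out lower numbers stand for stronger inhibition of growth and higher numbers for weaker inhibition of growth), and compound 1 gives 2300 nM. Compound 2 `O=S(=O)(NCCCNCc1ccc(Br)cc1)c1cc(C(F)(F)F)cc(C(F)(F)F)c1` differs only at one aromatic carbon, and in this assay compound 2 gives 2900 nM. Going by the values given here, the sole measured step, a 1.3-fold higher number from compound 1 to compound 2 (0.10 log units; within the scatter), is small, so compound 2 and compound 1 sit together within the ordinary scatter; compound 2 simply shows the higher of the two numbers. Compound 3 `O=S(=O)(NCCCNCc1ccc(-c2ccccc2)cc1)c1cc(C(F)(F)F)cc(C(F)(F)F)c1` is not yet measured; it arises from compound 2 by phenyl in place of bromo on an aromatic carbon. Among the compounds with values here, only the step from compound 1 to compound 2 bears on this change, since it replaces the group at the same spot, and it was within the scatter. The step of a 1.3-fold lower number from compound 2 to compound 3 (0.12 log units; within the scatter) is therefore expected to stay small, with no clear direction. For compound 3 the estimate in this assay is 2200 nM, with a range from 700 nM to 7000 nM.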

Compound 3, concentration for 50% growth inhibition: 2700 nM
Compound 3: the middle estimate sits 1.2-fold (0.09 log units) below what was measured, within the range that was stated.
By their numbers in this assay, from the lowest: compounds 1, 3 and 2 (each within the scatter of the next).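

Bromo and phenyl differ widely in size, with one heavy atom against six and no ring against an aromatic ring, yet in this assay the exchange on this aromatic carbon gives only a small step (in numbers: a 1.1-fold lower number from compound 2 to compound 3 (0.03 log units; within the scatter)). The third pair reads the same way (in numbers: a 1.2-fold higher number from compound 1 to compound 3 (0.07 log units; within the scatter)), so tert-butyl, bromo and phenyl, the three groups shown at this place, all give numbers within the scatter of one another, and none of the three stands apart. No measurement is at hand that would explain this flat result.

On these data alone, whether any group at this place can move the number beyond the scatter stays open. An amine, a carboxylic acid or a methoxy group on the same aromatic carbon could answer that, and so could a plain hydrogen.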